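This account rests on a few compounds, and the source may have more. Where it says the series, first, only, none or still open, it means among the compounds named here.

For the measured compounds named here, in a functional assay on CNE-2 cells (Homo sapiens) for inhibition, read by MTT assay, with a stated time of 72 h (a higher number here means a weaker inhibitor, a lower number a stronger inhibitor), compound 1 `Nc1nc2cc(-c3nn(CCCCCCCCCC(=O)NO)c4ncnc(N)c34)ccc2o1` gives 36800 nM, the higher of the two numbers measured so far and so the weaker inhibitor. Compound 2 `Nc1ncnc2c1c(-c1cnc3[nH]ccc3c1)nn2CCCCCCCCCC(=O)NO` gives 2200 nM. Compound 3 `Nc1nc2cc(-c3nn(CCCCCCCCC(=O)NO)c4ncnc(N)c34)ccc2o1` has not yet been measured. It keeps the core of compound 1 and changes only the end of the chain, with hydroxycarbamoyl in place of (hydroxycarbamoyl)methyl on a saturated chain carbon, eight bonds along the chain from an aromatic nitrogen. Going by the values given here, the only measured step, a 17-fold lower number from compound 1 to compound 2 (1.22 log units; beyond the scatter), swaps the aromatic group and leaves the chain untouched, so it shows how far the numbers can move but gives no direct measure of a chain change. Among the compounds with values here, with no measured chain step to go on, only a modest shift is expected, a 1.5-fold lower number from compound 1 to compound 3 (0.17 log units; within the scatter). For compound 3 the estimated value is 25000 nM, with an expected range of 7000 nM to 70000 nM.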

Compound 3, half-maximal inhibitory concentration: 3240 nM
The estimate for compound 3 lay 7.7-fold (0.89 log units) above the measured number, outside the stated range (below it).
By their numbers in this assay, from the lowest: compounds 2 and 3 (each within the scatter of the next); then compound 1.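

In this assay, changing only the chain end, with hydroxycarbamoyl in place of (hydroxycarbamoyl)methyl, gives a large step (an 11-fold lower number from compound 1 to compound 3 (1.06 log units; beyond the scatter)) on a saturated chain carbon, eight bonds along the chain from an aromatic nitrogen. Until now only a swap of the aromatic group had been seen to move the number (a 17-fold lower number from compound 1 to compound 2 (1.22 log units; beyond the scatter)), whereas here the core of compound 1 stays fixed and the chain alone changes, so chain length matters in this series as well. Nothing available here bears on the reason for this step.

The compounds shown leave open whether a still shorter chain or a longer one would move the number further, and whether a carboxylic acid at the chain end could stand in for hydroxycarbamoyl. They also leave open whether shortening the chain of compound 2 would give a step of similar size.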